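The source may hold more compounds than are shown below. What is called first, only, known or untested is meant among the compounds shown, and "the series" means these compounds.

Measured so far:
- compound 1 `O=c1[nH]cnc2c1c(-c1ccoc1)cn2[C@@H]1O[C@H](CO)[C@@H](O)[C@H]1O` — > 20000 nM
- compound 2 `Cc1ncnc2c1c(-c1cc3ccccc3o1)cn2[C@@H]1O[C@H](CO)[C@@H](O)[C@H]1O` — > 20000 nM
- compound 3 `Cc1ncnc2c1c(-c1ccoc1)cn2[C@@H]1O[C@H](CO)[C@@H](O)[C@H]1O` — > 20000 nM

In a functional assay on A549 cells (Homo sapiens), read by MTT assay, with a stated time of 72 h (a higher number here means a weaker inhibitor, a lower number a stronger inhibitor), compound 1 gives > 20000 nM, which is a limit of the assay and not a number. Compound 2 likewise gives > 20000 nM, a limit. Compound 3 gives > 20000 nM, again a limit. Hence the limit of > 20000 nM in this assay, at which 3 of the 3 values shown sit: every value in the series so far is a limit, and compound 1 stands at that limit with nothing to separate it from compound 2 or compound 3. Within the data shown here, the single one-place step measured, a step that the two limits leave unreadable from compound 2 to compound 3, has both of its ends at the limit, so its size cannot be read.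

Compound 4 `O=c1[nH]cnc2c1c(-c1ccco1)cn2[C@@H]1O[C@H](CO)[C@@H](O)[C@H]1O` differs from compound 1 by furan-2-yl in place of furan-3-yl on an aromatic carbon. Among the measured compounds shown here, no measured step touches this exchange of one furan attachment point for the other, and the one step in hand is unreadable, so no direction or size can be taken from the series; the only guide is that all three measured compounds sit at the limit. The expected step that the limit leaves unreadable from compound 1 to compound 4 is therefore set at none beyond the scatter. Compound 4 is estimated in this assay at 30000 nM, within a range of 12000 nM to 100000 nM, most probably reported again only as a limit.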

Compound 4, half-maximal inhibitory concentration: > 20000 nM
Compound 4: no number, only a limit (the forecaster's own chance of this, stated with the estimate: 85%); the middle value lies beyond the limit too.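

In this assay the exchange of furan-3-yl for furan-2-yl gives no readable step between compound 1 and compound 4, and the series stays at a single limit: the limit of > 20000 nM in this assay, at which 4 of the 4 values shown sit.

The compounds shown leave open whether any variant of the shared core gives a value inside the measurable range, and how furan-2-yl, furan-3-yl and 1-benzofuran-2-yl rank against one another.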